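Mirror-image ring carbon: compound 2 to compound 3

The compounds below may be only part of what the source reports. "The series", "measured", "known", "first", "only" and "open" are said of these compounds alone.

Measured compounds:
compound 1 `CCC[C@@H](OC(C)=O)C1=C(Br)[C@@](CI)(OC)OC1=O`: 7.1 ug/mL
compound 2 `CCC[C@@H](OC(C)=O)C1=C(Br)[C@@](OC)(C(Br)Br)OC1=O`: 6.2 ug/mL

Of the compounds shown here, two have been tested in a functional assay on KB cells (Homo sapiens) for cytotoxicity; on this read-out higher numbers stand for an effect only at larger amounts of compound and lower numbers for an effect already at smaller amounts. Compound 1 gives 7.1 ug/mL and compound 2 gives 6.2 ug/mL; the two numbers lie within the usual scatter of each other, so on the data at hand compound 2 and compound 1 cannot be told apart.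

Compound 3 `CCC[C@@H](OC(C)=O)C1=C(Br)[C@](OC)(C(Br)Br)OC1=O` has not yet been tested in this assay. It differs from compound 2 as follows: the two compounds have the same atoms and bonds and differ only in configuration as drawn: 1 of 2 stereo elements differ; a stereocentre at a saturated ring carbon is drawn S in compound 2 and R in compound 3. Among the measured compounds shown here, no measured pair in this set shows what such a change does here.

Because compound 2 gives 6.2 ug/mL and the change is one of configuration alone, the step of a 1.3-fold higher number from compound 2 to compound 3 (0.11 log units; within the scatter) is expected to be modest, most likely towards a somewhat higher number or none beyond the scatter. Compound 3 is therefore estimated at 8 ug/mL, with a range from 3 ug/mL to 25 ug/mL.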

Compound 3, concentration for half-maximal effect: 6.1 ug/mL
For compound 3 the middle estimate is 1.3-fold (0.12 log units) above the measured one; measured number inside the range.
By their numbers in this assay, from the lowest: compounds 3, 2 and 1 (each within the scatter of the next).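

In this assay the step is a 1.0-fold lower number from compound 2 to compound 3 (0.01 log units; within the scatter), so the configuration drawn at this saturated ring carbon makes no difference that this read-out can detect, and the pair isolates that single feature: the fact that compounds 2 and 3 differ only in the configuration as drawn

Changing the group on the same carbon, dibromomethyl in place of iodomethyl, gives a 1.2-fold lower number from compound 1 to compound 3 (0.07 log units; within the scatter). Both dibromomethyl compounds therefore lie within the scatter of the iodomethyl compound, whichever way the dibromomethyl compound is drawn at this carbon.

As far as these compounds go, it remains open whether configuration at this carbon would still show no detectable effect with a different group there, such as an amine, a carboxylic acid or a longer chain. From the compounds shown here alone, the second stereo element is the same in all three compounds, so the effect of inverting it is also open.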